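The source may hold more compounds than are shown below. What is called first, only, known or untested is meant among the compounds shown, and "the series" means these compounds.

Measured compounds:
compound 1 `CCCCCCCCCCCCCCC(N)COCc1ccccc1`, which in an ADME assay on cells (Splenocyte, Mus musculus, strain BALB/c) for cytotoxicity, read by MTT assay, tested at 1 ug/mL (on this read-out higher numbers stand for a stronger effect at the one concentration tested and lower numbers for a weaker effect), gives 0%
compound 2 `CCCCCCCCCCCCCCC(COCc1ccccc1)NCC`, for which this assay gives "not determined" (no result reported)
compound 3 `CCCCCCCCCCCCCCC(COCc1ccccc1)NC(=O)CCCC(=O)OC`, for which this assay gives "not determined" (no result reported)

Within the data shown here, only one of the three compounds, compound 1, carries a number in this assay, and that number sits at the bottom of the scale. Compound 2 and compound 3 have no result; nothing can be said of how compound 3 compares with compound 1 or compound 2. The sole anchor for the series is therefore the result of compound 1 in this assay.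

The step from compound 3 to compound 4 `CCCCCCCCCCCCCCC(COCc1ccccc1)NC(=O)CCCC(=O)O` is a small one: hydrogen in place of methyl on an oxygen next to a carbonyl group. Among the measured compounds shown here, with no measured pair of this kind, the size of the step in this assay cannot be read from the data. Since the only numerical result in the series is the result of compound 1 in this assay, which is as low as the read-out allows, the expectation for compound 4 is a likewise weak effect, with any step between compound 3 and compound 4 most likely lying within the scatter. Compound 4 is therefore estimated to give 5% in this assay, with a range from 0% to 20%.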

Compound 4, a percentage reported as activity, at one concentration (the size of the read-out at that concentration, not a potency): 0%
Beside the measured number, compound 4's estimate is 5 percentage points above it, within the range that was stated.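

Among these compounds, compound 1 had been the only number, and compound 4 now adds a second: with (3-carboxypropyl)carbonyl in place of hydrogen on an amine nitrogen, this assay shows no change at the digits printed from compound 1 to compound 4 (within the scatter). At the one concentration tested, this amine nitrogen therefore takes a substituent of this size and bearing a carboxy end without lifting the read-out from the bottom of the scale, although a pair sitting at that bottom gives no measure of how the two compounds might differ under conditions where an effect appears; the step from methoxycarbonyl to carboxy, and every other step involving compound 2 or compound 3, cannot be read. Nothing in the material at hand offers an explanation for this result.

The compounds shown leave open whether an acetyl group, a sulfonyl group or a longer chain ending in a carboxylic acid on the same nitrogen would give a read-out above the bottom of the scale. They also leave open whether a primary alcohol in place of the benzyloxy end of the shared core would do so.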